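The source may report more compounds than this note shows. Statements on the series, on what has been measured and on what is new or still open speak of the compounds shown alone.

Measured so far:
compound 1, `CS/C(=N\C(=O)c1ccno1)NC(=O)c1ccno1` — > 100000 nM
compound 2, `CS/C(=N\C(=O)c1ccco1)NC(=O)c1ccco1` — > 100000 nM
compound 3, `O=C(/N=C(/NC(=O)c1ccno1)[Se]Cc1ccccc1)c1ccno1` — > 100000 nM

Of the compounds shown here, three have been tested in a functional assay on HT-29 cells (Homo sapiens) for cytotoxicity, read by MTT assay, with a stated time of 72 h; on this read-out lower numbers stand for higher toxicity in this test and higher numbers for lower toxicity in this test. In this assay compound 1 gives > 100000 nM, which is a limit of the assay and not a number. Compound 2 gives > 100000 nM in this assay, again a limit. Compound 3 gives > 100000 nM in this assay, also a limit.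

Compound 3 differs from compound 1 by a group of 8 heavy atoms (7 carbon, 1 selenium; one six-membered aromatic ring of carbon only) in place of a group of 2 heavy atoms (1 carbon, 1 sulfur; no ring), on a carbon with a double bond to nitrogen. The step this change made, a step that the two limits leave unreadable from compound 1 to compound 3, cannot be read, since both ends sit at a limit; what is known is only that (the limit of > 100000 nM in this assay, at which 3 of the 3 values shown sit). Compound 1 and compound 2 have different cores, and the difference between the two cores is not broken down here.

The untested compound 4, `O=C(/N=C(/NC(=O)c1ccco1)[Se]Cc1ccccc1)c1ccco1`, stands to compound 2 as compound 3 stands to compound 1: it carries a group of 8 heavy atoms (7 carbon, 1 selenium; one six-membered aromatic ring of carbon only) in place of a group of 2 heavy atoms (1 carbon, 1 sulfur; no ring), on a carbon with a double bond to nitrogen, the same change on the same kind of carbon. Among the measured compounds shown here, no measured step in this assay offers a size to carry over, because a step that the two limits leave unreadable from compound 1 to compound 3 is unreadable and because of the limit of > 100000 nM in this assay, at which 3 of the 3 values shown sit. The expectation for compound 4 therefore rests on the fact that compound 2 gave > 100000 nM, a limit, and that the same change left compound 3 at a limit as well. The step expected is a step that the limit leaves unreadable from compound 2 to compound 4, which is to say compound 4 is expected to give 200000 nM, with a likely range from 50000 nM to 1000000 nM, and most probably only a limit will be reported.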

Compound 4, concentration lethal to 50% of the cells: 89100 nM
Compound 4: the middle estimate sits 2.2-fold (0.35 log units) above what was measured; the range from low to high includes it.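

In this assay, replacing methylsulfanyl with the selenium-bearing group and its six-membered aromatic ring, on a carbon with a double bond to nitrogen, gives an at least 1.1-fold lower number from compound 2 to compound 4 (0.05 log units; that floor lies within the scatter). On these data alone, this shows that on the core of compound 2 the change ends in a measured number and not in a limit, but the floor of the step does not by itself establish a change beyond the usual scatter, and the true size of the step stays unknown. The same change on the core of compound 1 cannot be read, so the data show neither that the change carries over from one core to the other nor that it fails to, because both steps are bounded by a limit and only one has even a floor: the limit of > 100000 nM in this assay, at which 3 of the 4 values shown sit.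

The compounds shown leave open whether the selenium or the six-membered aromatic ring goes with the number for compound 4, as the change brings in both at once. They also leave open what an amine or a longer alkyl chain would give in place of methylsulfanyl on that carbon, on either core.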